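Urea series: dichlorophenyl analogue of compound 2

The compounds below may be only part of what the source reports. "The series", "measured", "known", "first", "only" and "open" are said of these compounds alone.

compound 1 `COc1cc2cc(Oc3ccc(NC(=O)Nc4cccc(C(F)(F)F)c4)cc3)c(C)nc2cc1OC` — > 50000 nM
compound 2 `COc1cc2cc(Oc3ccc(NC(=O)Nc4ccc(Cl)c(C(F)(F)F)c4)cc3)c(C)nc2cc1OC` — 27400 nM

Two measured compounds share one core. In a functional assay on Hs-578T cells (Homo sapiens) for inhibition, read by sulforhodamine B assay, with a stated time of 48 h (a higher number here means that more compound is tolerated, a lower number that less compound is tolerated), compound 1 gives only a limit, > 50000 nM. In this assay, among the measured compounds shown here, compound 2 gives 27400 nM, the only number. For the measured compounds named here, the single measured comparison is an at least 1.8-fold lower number from compound 1 to compound 2 (0.26 log units; that floor lies within the scatter); it rests on (the limit of > 50000 nM in this assay, at which 1 of the 2 values shown sits), so its true size remains open.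

Compound 3, `COc1cc2cc(Oc3ccc(NC(=O)Nc4ccc(Cl)c(Cl)c4)cc3)c(C)nc2cc1OC`, differs from compound 2 by chloro in place of trifluoromethyl on an aromatic carbon. Going by the values given here, no measured step exchanges trifluoromethyl for chloro; the step from compound 1 to compound 2 touches the same ring but a different group and gives no direction for this change. The expectation for compound 3 in this assay is therefore a step within the scatter, a 1.1-fold higher number from compound 2 to compound 3 (0.04 log units; within the scatter). Compound 3 is estimated at 30000 nM, with a range from 12000 nM to 75000 nM.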

Compound 3, concentration lethal to 50% of the cells: > 100000 nM
Compound 3: only a limit was reported; the forecaster's own chance of this, stated with the estimate: 35%; at least 3.3-fold (0.52 log units) between middle value and limit.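

Exchanging trifluoromethyl for chloro on this aromatic carbon, ortho to a chloro group and meta to a large group, gives an at least 3.6-fold higher number from compound 2 to compound 3 (0.56 log units; beyond the scatter) in this assay. This is the first step in the series that is shown to lie beyond the scatter, so the result at this position is not indifferent to which of these two groups sits there. Compound 3 has only a limit, so the step gives a floor and its full size remains open: the limit of > 100000 nM in this assay, at which 1 of the 3 values shown sits.

The step from compound 1 to compound 3 cannot be read, as both ends are limits. Also open, from the compounds shown here alone, is how a nitrile or an amine in place of trifluoromethyl on this carbon would read in this assay, and whether any such group would give a number rather than a limit.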